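A few compounds are considered here, and "the series" means these few. Any claim that something is new, unique, unknown or untested is made for them only; others in the source may bear on it.

Working notes on the series. The shared core carries a phenyl group and a variable substituent on the aromatic carbon ortho to a phenyl group, next to the ring nitrogen. Compound 1 `Nc1cc(N)c2nc(-c3ccccc3)c(Sc3ccc(F)cc3)nc2c1` bears a (4-fluorophenyl)sulfanyl group there; in a functional assay on IGROV-1 cells (Homo sapiens) for inhibition, read by sulforhodamine B assay, with a stated time of 48 h (on this read-out lower numbers stand for stronger inhibition of growth and higher numbers for weaker inhibition of growth), compound 1 gives 25100 nM. Compound 2 `CCOC(=O)[C@H](CCC(=O)O)NC(=O)c1ccc(Oc2nc3cc(N)cc(N)c3nc2-c2ccccc2)cc1` carries a larger amide-bearing side chain in the same place; in this assay compound 2 gives 18200 nM. Compound 3 `CCOC(=O)[C@H](CCC(=O)O)NC(=O)c1ccc(CNc2nc3cc(N)cc(N)c3nc2-c2ccccc2)cc1` carries a related side chain through a benzylamino link; in this assay compound 3 reaches only a limit of the assay, < 100000 nM, as the limit of < 100000 nM in this assay, at which 1 of the 3 values shown sits, records. Of the two numbers available, compound 1 has the higher one, with compound 2 the nearest at a gap within the scatter, so no order between them can be read. Compound 4 `Nc1cc(N)c2nc(-c3ccccc3)c(NCc3ccc(F)cc3)nc2c1` is not yet measured. It differs from compound 1 in one place: (4-fluorobenzyl)amino in place of (4-fluorophenyl)sulfanyl on an aromatic carbon. For the measured compounds named here, no measured pair shows this change directly, and compound 3, the only other benzylamino compound, gives only a limit. From compound 1 to compound 4 the step in this assay is expected to be modest, a 1.2-fold higher number from compound 1 to compound 4 (0.08 log units; within the scatter), with no clear direction beyond the scatter. Compound 4 is estimated at 30000 nM, between 10000 nM and 100000 nM.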

Compound 4, concentration for 50% growth inhibition: 3090 nM
Beside the measured number, compound 4's estimate is 9.7-fold (0.99 log units) above it; measured number outside the range, below it.
By their numbers in this assay, from the lowest: compound 4; then compounds 2 and 1 (each within the scatter of the next).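

In this assay, for the compounds shown here, (4-fluorobenzyl)amino in place of (4-fluorophenyl)sulfanyl gives an 8.1-fold lower number from compound 1 to compound 4 (0.91 log units; beyond the scatter), the first step that lies beyond the scatter, so the group at this position can move the read-out. The fluorinated aromatic ring stays in both compounds; the link changes, with sulfur leaving and nitrogen and a further carbon entering, and the entering group carries a hydrogen-bond donor that the leaving group lacks. Nothing shown accounts for this step.

From the compounds shown here alone, whether the step follows the nitrogen or the added carbon stays open, and a (4-fluorophenyl)amino group or a methylated benzylamino nitrogen would help to separate the two. Going by these compounds alone, compound 3, the other benzylamino compound, gives only a limit of the assay, < 100000 nM, and so fixes no step.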